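This account rests on a few compounds, and the source may have more. Where it says the series, first, only, none or still open, it means among the compounds named here.

Measured so far in a functional assay on KG-1 cells (Homo sapiens) for antiproliferative activity, read by CCK-8 assay, with a stated time of 72 h; a lower number here means a stronger inhibitor, a higher number a weaker inhibitor:
- compound 1 `COc1ccc(F)c(-c2ccc3c(NC(=O)c4ccc(N(C)CCN(C)C)cc4)n[nH]c3c2)c1F`: 333 nM
- compound 2 `COc1cccc(-c2ccc3c(NC(=O)c4ccc(N5CCN(C)CC5)cc4F)n[nH]c3c2)c1F`: > 1000 nM
- compound 3 `CCN1CCN(c2ccc(C(=O)Nc3n[nH]c4cc(-c5c(F)cc(F)c(OC)c5F)ccc34)cc2)CC1`: > 1000 nM

Within the data shown here, compound 1 is the only member of the set with a numerical value in this assay. Compound 2 returns only a limit. Compound 3 likewise returns only a limit, so two of the three entries sit at the limit of > 1000 nM in this assay, at which 2 of the 3 values shown sit.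

Compound 4 `CCN1CCN(c2ccc(C(=O)Nc3n[nH]c4cc(-c5c(F)ccc(OC)c5F)ccc34)cc2)CC1` shares the core of compound 1 and differs by 4-ethylpiperazin-1-yl in place of (2-(dimethylamino)ethyl)(methyl)amino on an aromatic carbon. Among the measured compounds shown here, no measured pair isolates this change. Compound 3 already carries the 4-ethylpiperazin-1-yl group and gives only a limit, which leans toward a weakening. A step from compound 1 to compound 4 of a 3.0-fold higher number from compound 1 to compound 4 (0.48 log units; beyond the scatter) is expected, beyond the scatter. Compound 4 is estimated at 1000 nM, within 300 nM to 3000 nM.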

Compound 4, half-maximal inhibitory concentration: 25.3 nM
Compound 4: the middle estimate sits 40-fold (1.60 log units) above what was measured; the measured number lies below the stated range.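

In this assay, 4-ethylpiperazin-1-yl in place of (2-(dimethylamino)ethyl)(methyl)amino on an aromatic carbon gives a 13-fold lower number from compound 1 to compound 4 (1.12 log units; beyond the scatter), so this group is compatible with strong activity on the shared core. Hydrogen in place of fluoro on an aromatic carbon gives an at least 39-fold lower number from compound 3 to compound 4 (1.59 log units; beyond the scatter), so with 4-ethylpiperazin-1-yl held constant, that single fluoro separates the two outcomes. Compound 3 gives a limit, not a number: the limit of > 1000 nM in this assay, at which 2 of the 4 values shown sit.

On these data alone, whether a morpholine in the place of 4-ethylpiperazin-1-yl would keep this level stays open. So does whether removing that fluoro has a comparable effect alongside (2-(dimethylamino)ethyl)(methyl)amino.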